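The compounds below may be only part of what the source reports. "The series", "measured", "known", "first", "only" and "open" are said of these compounds alone.

Measured so far:
compound 1 `CC(C)[C@H](C(=O)Nc1ccccc1)c1ccc(Cl)cc1` — < 30%
compound 2 `CC(C)C(C(=O)Nc1cnccn1)c1ccc(Cl)cc1` — 115%

In a functional assay on CHO cells for agonist activity at Free fatty acid receptor 2 (Homo sapiens), read by cAMP accumulation (on this read-out higher numbers stand for larger maximal responses and lower numbers for smaller maximal responses), compound 1 returns only a limit of the assay, < 30%, and so stands at the limit of < 30% in this assay, at which 1 of the 2 values shown sits. In this assay compound 2 gives 115%. Compound 3 `Cc1csc(NC(=O)[C@H](c2ccc(Cl)cc2)C(C)C)n1` is not yet measured; it differs from compound 1 by 4-methyl-1,3-thiazol-2-yl in place of phenyl on an amide-type nitrogen. For the measured compounds named here, no measured step covers this change; the two known values show only that compound 2 gives a full response where compound 1 does not rise above its limit. The step of a number at least 50 percentage points higher from compound 1 to compound 3 (beyond the scatter) is expected to be upward and beyond the scatter. Compound 3 is expected to reach 80%, within 30% to 120%.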

Compound 3, largest response reached (reported as efficacy), in percent of the reference or control that the assay uses: 87%
Compound 3: the middle estimate sits 7 percentage points below what was measured, and the stated range covers the measured number.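

In this assay, for the compounds shown here, the first one-place comparison shows that the group on the amide-type nitrogen matters: 4-methyl-1,3-thiazol-2-yl in place of phenyl gives a number at least 57 percentage points higher from compound 1 to compound 3 (beyond the scatter). The entering ring brings hetero atoms and hydrogen-bond acceptors that phenyl lacks, but the data do not tie the step to either. The step is a bound rather than an exact size, because compound 1 gives only a limit of the assay: the limit of < 30% in this assay, at which 1 of the 3 values shown sits.

Going by these compounds, it remains open whether the ring or its methyl carries the gain. How an unsubstituted 1,3-thiazol-2-yl, or an amine or carboxylic acid in place of that methyl, would read is also unresolved.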